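This account rests on a few compounds, and the source may have more. Where it says the series, first, only, none or still open, it means among the compounds named here.

Compound 1, whose structure is `COc1ccc(C(=NNC(=O)NNC(=O)NCCCC(C)Nc2cc(OC)cc3cccnc23)c2ccc(OC)cc2)cc1`, was tested in a functional assay on SW-620 cells (Homo sapiens) for inhibition, read by MTT assay, with a stated time of 4 days; on this read-out lower numbers stand for stronger inhibition and higher numbers for weaker inhibition. In this assay compound 1 gives only a limit, >= 100000 nM, and no number. Compound 2, whose structure is `COc1cc(NC(C)CCCNC(=O)NNC(=O)N(CCO)CCO)c2ncccc2c1`, was tested in the same way. In this assay compound 2 likewise reaches only a limit, > 100000 nM, so its standing is known merely as a bound and not as a value. Of the two results shown, one sits at the limit of > 100000 nM in this assay, at which 1 of the 2 values shown sits, and the other at the limit of >= 100000 nM in this assay, at which 1 of the 2 values shown sits; neither compound has a measured number, and nothing separates the two.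

Compound 3, whose structure is `COc1cc(NC(C)CCCNC(=O)Nc2ccc(Cl)c(C(F)(F)F)c2)c2ncccc2c1`, has not yet been measured in this assay. It differs from compound 2 in one place: 4-chloro-3-(trifluoromethyl)phenyl in place of (bis(2-hydroxyethyl)carbamoyl)amino on an amide-type nitrogen. Within the data shown here, no step between measured compounds is available to judge this change, so the size of the step can only be expected. A gain in potency from compound 2 to compound 3 of about an at least 5.0-fold lower number from compound 2 to compound 3 (0.69 log units; beyond the scatter) is expected, beyond the usual scatter. Compound 3 is estimated to give 20000 nM in this assay, within a range from 3000 nM to 100000 nM.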

Compound 3, half-maximal inhibitory concentration: 23000 nM
Estimate against measurement, compound 3: 1.2-fold (0.06 log units) below, within the range that was stated.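

Compound 3 is the first compound shown to give a number rather than a limit in this assay, with compound 3 at 23000 nM, so a change on this amide-type nitrogen can bring a measurable value. Putting 4-chloro-3-(trifluoromethyl)phenyl in place of (bis(2-hydroxyethyl)carbamoyl)amino gives an at least 4.3-fold lower number from compound 2 to compound 3 (0.63 log units; beyond the scatter), which shows that the group at this place alone can carry a step beyond the scatter while the shared core stays the same. The reading for compound 2 is a limit and not a number: the limit of > 100000 nM in this assay, at which 1 of the 3 values shown sits.

The compounds shown leave open whether an unsubstituted phenyl, a cyclohexyl ring or a simple alkyl chain on the same nitrogen would give a value like that of compound 3, and so whether the aromatic ring itself or its chloro and trifluoromethyl substituents carry the step. Also open, from the compounds shown here alone, is how a carboxylic acid or an amine on that ring, or a longer chain between the shared core and the carbonyl, would read in this assay.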